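The source may report more compounds than this note shows. Statements on the series, on what has been measured and on what is new or still open speak of the compounds shown alone.

In a functional assay (aorta) with Rattus norvegicus as the target (on this read-out higher numbers stand for weaker inhibition and lower numbers for stronger inhibition), compound 1 (`CCCCN(CCCC)CCCCOc1ccc(S(=O)(=O)c2c(C(C)C)cn3ccccc23)cc1`) gives 20.2 nM and compound 2 (`COc1ccc(CNCCCOc2ccc(S(=O)(=O)c3c(C(C)C)cn4ccccc34)cc2)cc1OC`) gives 13 nM. These two values lie within the scatter of each other. Compound 3 (`CCCCN(CCCC)CCCCOc1ccc(S(=O)(=O)c2c(CC)cn3ccccc23)cc1`) alters compound 1 in a single place: hydrogen in place of methyl on a saturated chain carbon bound to an aromatic carbon and a saturated chain carbon. Put simply, isopropyl becomes ethyl. For the measured compounds named here, the only measured step, a 1.6-fold lower number from compound 1 to compound 2 (0.19 log units; within the scatter), lies elsewhere in the molecule and within the scatter. Going by the values given here, no measured step touches this place, and no shift beyond the scatter is expected in this assay. The expected step is a 1.4-fold higher number from compound 1 to compound 3 (0.14 log units; within the scatter). For compound 3 the estimated value is 28 nM, with an expected range of 10 nM to 80 nM.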

Compound 3, half-maximal inhibitory concentration: 33.3 nM
The estimate for compound 3 lay 1.2-fold (0.08 log units) below the measured number; measured number inside the range.
By their numbers in this assay, from the lowest: compounds 2, 1 and 3 (each within the scatter of the next, the first and the last beyond it).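

Shortening isopropyl to ethyl gives the first reading at this position: in this assay the step stays within the scatter (a 1.6-fold higher number from compound 1 to compound 3 (0.22 log units; within the scatter)). Removing this one methyl therefore causes no clear loss of inhibition, at least with the side chain of compound 1. No evidence here explains this result. Still open, from the compounds shown here alone, is how much larger or different a group this place accepts, such as tert-butyl or phenyl. Going by these compounds, it is also open whether ethyl gives the same result with the (3,4-dimethoxybenzyl)amino chain of compound 2.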